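The compounds below may be only part of what the source reports. "The series", "measured", "known", "first", "only" and "open" are said of these compounds alone.

Measured compounds:
- Compound 1, `O=C(/C=C/c1ccc2c(c1)B(O)OC2)c1ccc(F)cc1`: 2800 nM
- Compound 2, `O=C(/C=C/c1ccc2c(c1)B(O)OC2)c1ccc(Cl)cc1`: 9300 nM
- Compound 3, `O=C(/C=C/c1ccc2c(c1)B(O)OC2)c1ccc(O)c(O)c1`: > 100000 nM

All three share one core and differ only in the groups on the outer aromatic ring. In a functional assay on HCT-116 cells (Homo sapiens) for cytotoxicity, read by MTT assay, with a stated time of 48 h (a lower number here means a stronger inhibitor, a higher number a weaker inhibitor), compound 1 gives 2800 nM. In this assay compound 2 gives 9300 nM. Going by the values given here, the one measured step between neighbours, a 3.3-fold higher number from compound 1 to compound 2 (0.52 log units; beyond the scatter), is modest in size.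

Compound 3 stands apart. In this assay compound 3 gives > 100000 nM, which is a limit of the assay and not a number. Compound 3 thus sits at the limit of > 100000 nM in this assay, at which 1 of the 3 values shown sits.

Compound 4, `O=C(/C=C/c1ccc2c(c1)B(O)OC2)c1cccc(O)c1`, has not yet been measured in this assay. It differs from compound 3 by hydrogen in place of hydroxy on an aromatic carbon. Among the compounds with values here, no measured step covers the loss of a hydroxy group, so the only step available, from a halogen to a halogen, does not bear on it directly. With compound 3 at a limit, the direction of the expected change is toward a lower number, but its size is uncertain.

Compound 4 is expected at 30000 nM in this assay, within 8000 nM to 100000 nM. This estimate implies a step of an at least 3.3-fold lower number from compound 3 to compound 4 (0.52 log units; beyond the scatter).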

Compound 4, half-maximal inhibitory concentration: 6500 nM
The estimate for compound 4 lay 4.6-fold (0.66 log units) above the measured number; measured number outside the range, below it.
By their numbers in this assay, from the lowest: compound 1; then compounds 4 and 2 (each within the scatter of the next). At a limit, above all of these: compound 3.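

In this assay, hydrogen in place of the hydroxy group that stands para to a large group gives an at least 15-fold lower number from compound 3 to compound 4 (1.18 log units; beyond the scatter), so a change at this single position on the outer ring can shift the number further than the swap between the two halogens did. Compound 3 stands at a limit and not at a number, so this step has no exact size: the limit of > 100000 nM in this assay, at which 1 of the 4 values shown sits. The hydroxy group that remains in compound 4 does not by itself rule out activity, since the comparison with the chloro compound gives a 1.4-fold lower number from compound 2 to compound 4 (0.16 log units; within the scatter), although the comparison with the fluoro compound gives a 2.3-fold higher number from compound 1 to compound 4 (0.37 log units; beyond the scatter).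

The compounds shown leave open whether the weak result for compound 3 depends on having two hydroxy groups together or on a hydroxy group at the para position alone. They also leave open how an amine, a methoxy group or a carboxylic acid would behave on this ring, and they cannot tell why removing the hydroxy group changes the result in these cells.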